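The source may report more compounds than this note shows. Statements on the series, on what has been measured and on what is new or still open speak of the compounds shown alone.

Working notes on the series. Among the compounds with values here, in a functional assay on ACHN cells (Homo sapiens) for antiproliferative activity, read by sulforhodamine B assay (a lower number here means a stronger inhibitor of growth, a higher number a weaker inhibitor of growth), compound 1 `CC(C)(C)CCOc1cccc(O)c1C(=O)/C=C/c1ccc(C(=O)O)cc1` gives 8450 nM, the only true number so far. Compound 2 `CCCCOc1cccc(O)c1C(=O)/C=C/c1ccc(O)cc1` reads > 30000 nM in this assay, and that entry is a limit of the assay, not a number. Compound 1 is therefore the single measured reference point. The next step leads to compound 3 `CC(C)(C)CCOc1cccc(O)c1C(=O)/C=C/c1ccc(S(N)(=O)=O)cc1`, with sulfamoyl in place of carboxy on an aromatic carbon, para to a large group (sulfamoyl in place of carboxy on an aromatic carbon). No measured step sizes this exchange, so the expectation rests on compound 1 at 8450 nM alone. No shift beyond the scatter is expected in either direction, and the estimated step is a 1.1-fold lower number from compound 1 to compound 3 (0.05 log units; within the scatter). For compound 3 the expected value is 7500 nM, with an estimated range of 2500 nM to 25000 nM.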

Compound 3, concentration for 50% growth inhibition: 3300 nM
Beside the measured number, compound 3's estimate is 2.3-fold (0.36 log units) above it; low and high end bracket the measured number.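

In this assay, within the data shown here, the step of a 2.6-fold lower number from compound 1 to compound 3 (0.41 log units; beyond the scatter) is the first sized change at this position, on an aromatic carbon, para to a large group, and it favours sulfamoyl in place of carboxy. With the rest of compound 1 unchanged, this position is not tied to carboxy for growth inhibition, although a single pair gives one direction for one exchange and no trend. Nothing measured here bears on why the number falls, so the step has no stated cause.

On these data alone, whether an N-methyl sulfonamide, a methyl sulfone or a nitrile at this place would hold or extend the step remains open. Also open, as far as these compounds go, is how an amine at this place, or a longer chain on the ether oxygen, would read with sulfamoyl in place.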